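Swapping a halogen for trifluoromethyl on a flavone-benzothiazole hybrid

This account rests on a few compounds, and the source may have more. Where it says the series, first, only, none or still open, it means among the compounds named here.

For the measured compounds named here, compound 1 `O=c1cc(-c2ccccc2)oc2cc(OCCCCNc3nc4ccc(Cl)cc4s3)cc(O)c12` is one of three compounds measured in a physicochemical assay, read by spectrophotometry, with a stated time of 10 min (a higher number here means a weaker inhibitor, a lower number a stronger inhibitor), where compound 1 gives 4.16 ug/mL. Compound 2 `O=c1cc(-c2ccccc2)oc2cc(OCCCCNc3nc4ccc(F)cc4s3)cc(O)c12` gives 5.25 ug/mL and compound 3 `O=c1cc(-c2ccccc2)oc2cc(OCCCCNc3nc4c(F)cc(F)cc4s3)cc(O)c12` gives 5.76 ug/mL, so compound 1 holds the lowest number, though every gap sits inside the scatter. Compound 4 `O=c1cc(-c2ccccc2)oc2cc(OCCCCNc3nc4ccc(C(F)(F)F)cc4s3)cc(O)c12` has not yet been measured; it differs from compound 1 by trifluoromethyl in place of chloro on an aromatic carbon. Going by the values given here, the steps that bear on this change are a 1.3-fold higher number from compound 1 to compound 2 (0.10 log units; within the scatter), a 1.4-fold higher number from compound 1 to compound 3 (0.14 log units; within the scatter) and a 1.1-fold higher number from compound 2 to compound 3 (0.04 log units; within the scatter), all small. Since changing the substituent on this ring has so far left this assay unmoved, a step of a 1.1-fold higher number from compound 1 to compound 4 (0.04 log units; within the scatter) is expected, no larger than the scatter. Compound 4 is therefore estimated at 4.6 ug/mL, within 2.5 ug/mL to 8.5 ug/mL.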

Compound 4, half-maximal inhibitory concentration: 4.95 ug/mL
Beside the measured number, compound 4's estimate is 1.1-fold (0.03 log units) below it, and the stated range covers the measured number.
By their numbers in this assay, from the lowest: compounds 1, 4, 2 and 3 (each within the scatter of the next).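

Trifluoromethyl brings four heavy atoms where chloro has one, yet this assay records a 1.2-fold higher number from compound 1 to compound 4 (0.08 log units; within the scatter) and a 1.1-fold lower number from compound 2 to compound 4 (0.03 log units; within the scatter) for this change. So on this ring carbon, even a group with more heavy atoms than either halogen leaves the number within the scatter, which the halogen swaps alone could not show. Nothing measured here explains this result.

From the compounds shown here alone, every substituent at this place is a halogen or trifluoromethyl, so whether an amine or a carboxylic acid there would move the number remains open. Going by these compounds, the effect of a longer chain on the shared core also remains open.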